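The compounds below may be only part of what the source reports. "The series", "measured", "known", "first", "only" and "open" are said of these compounds alone.

Measured compounds:
- Compound 1, `Cn1cc(C2=C(c3nn(CCn4ccnc4)c4ncccc34)C(=O)NC2=O)c2ccccc21`: in a functional assay on A549 cells (Homo sapiens) for antiproliferative activity, read by MTT assay, with a stated time of 48 h (a lower number here means a stronger inhibitor, a higher number a weaker inhibitor), compound 1 gives > 100000 nM, which is a limit of the assay rather than a number.
- Compound 2, `CN(C)CCCn1nc(C2=C(c3cn(C)c4ccccc34)C(=O)NC2=O)c2cccnc21`: in this assay compound 2 gives > 100000 nM, again a limit rather than a number.
- Compound 3, `CN(C)CCCn1nc(C2=C(c3cn(C)c4ccccc34)C(=O)N(c3ccccc3)C2=O)c2cccnc21`: in this assay compound 3 gives 13000 nM.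

Within the data shown here, compound 3 thus carries the only number among the three; the other two values rest at the limit of > 100000 nM in this assay, at which 2 of the 3 values shown sit. Among the measured compounds shown here, the one readable step, an at least 7.6-fold lower number from compound 2 to compound 3 (0.88 log units; beyond the scatter), concerns the phenyl on the ring nitrogen and is not the change considered here. Compound 4, `Cn1cc(C2=C(c3nn(CCn4ccnc4)c4ncccc34)C(=O)N(c3ccccc3)C2=O)c2ccccc21`, differs from compound 3 by 1H-imidazol-1-yl in place of (dimethylamino)methyl on a saturated chain carbon, two bonds along the chain from an aromatic nitrogen. For the measured compounds named here, the only measured pair touching this change is a step that the two limits leave unreadable from compound 1 to compound 2, which runs in the reverse direction and, with both values at a limit, shows no size at all. Going by the values given here, no other measured step bears on the change. Compound 4 is therefore expected to sit close to compound 3, with no step beyond the scatter, at an estimated 13000 nM within 4000 nM to 50000 nM. That estimate means a step of no change at the digits printed from compound 3 to compound 4 (within the scatter).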

Compound 4, half-maximal inhibitory concentration: 43100 nM
The estimate for compound 4 lay 3.3-fold (0.52 log units) below the measured number; the measured number falls inside the stated range.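

Among these compounds, with phenyl on the amide-type nitrogen in the ring, the exchange of (dimethylamino)methyl for 1H-imidazol-1-yl on a saturated chain carbon can be read for the first time in this assay: it gives a 3.3-fold higher number from compound 3 to compound 4 (0.52 log units; beyond the scatter). The phenyl change, so far seen with the 3-(dimethylamino)propyl chain, now also appears with the 2-(1H-imidazol-1-yl)ethyl chain, giving an at least 2.3-fold lower number from compound 1 to compound 4 (0.36 log units; beyond the scatter). Both steps with phenyl point the same way: the same change on two cores in this assay, an at least 7.6-fold lower number (0.88 log units; beyond the scatter) from compound 2 to compound 3 and an at least 2.3-fold lower number (0.36 log units; beyond the scatter) from compound 1 to compound 4; the limit leaves it open whether they differ.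

On these data alone, without phenyl, the exchange of the two chain ends cannot be read, and the full size of each phenyl step stays unknown: the limit of > 100000 nM in this assay, at which 2 of the 4 values shown sit. The compounds shown also leave open whether a morpholine or a carboxylic acid at the chain end, or a longer chain, would keep the number of compound 3 or move it.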